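Swapping an acetoxy for chloro on a chromone scaffold

The source may hold more compounds than are shown below. What is called first, only, known or untested is meant among the compounds shown, and "the series" means these compounds.

In a functional assay on A549 cells (Homo sapiens) for cytotoxicity, with a stated time of 48 h (on this read-out lower numbers stand for stronger inhibition and higher numbers for weaker inhibition), compound 1 `CC(=O)Oc1ccc2oc(/C=C/[S+](C)[O-])cc(=O)c2c1` gives 4100 nM, the highest number of the three compounds measured. Compound 2 `CC(C)COc1ccc2oc(/C=C/[S+](C)[O-])cc(=O)c2c1` gives 1100 nM, and compound 3 `C[S+]([O-])/C=C/c1cc(=O)c2cc(F)ccc2o1` gives 2100 nM. The change to compound 4 `C[S+]([O-])/C=C/c1cc(=O)c2cc(Cl)ccc2o1` is chloro in place of acetoxy on an aromatic carbon. The closest guide is the replacement of the same acetoxy by another halogen, which gave a 2.0-fold lower number from compound 1 to compound 3 (0.29 log units; within the scatter); the more remote replacement of the acetyl by isobutyl gave a 3.7-fold lower number from compound 1 to compound 2 (0.57 log units; beyond the scatter). On this basis the expected shift is small, probably within the scatter, leaning toward a lower number, which as an estimate is a 2.1-fold lower number from compound 1 to compound 4 (0.31 log units; beyond the scatter). Compound 4 is therefore expected to give about 2000 nM, with a plausible range from 800 nM to 5000 nM.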

Compound 4, half-maximal inhibitory concentration: 1700 nM
For compound 4 the middle estimate is 1.2-fold (0.07 log units) above the measured one; the range from low to high includes it.
By their numbers in this assay, from the lowest: compounds 2, 4, 3 and 1 (each within the scatter of the next, the first and the last beyond it).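

In this assay, chloro at this position gives a 2.4-fold lower number from compound 1 to compound 4 (0.38 log units; beyond the scatter), so this halogen, unlike the fluoro of compound 3, stands clear of the scatter from the acetoxy of compound 1. The two halogens cannot be told apart, with a 1.2-fold lower number from compound 3 to compound 4 (0.09 log units; within the scatter). Chloro also cannot be separated from isobutoxy, with a 1.5-fold higher number from compound 2 to compound 4 (0.19 log units; within the scatter), so three different groups here give numbers within the scatter of their neighbours.

How an amine or a carboxylic acid on this aromatic carbon would behave stays open, and nothing given here accounts for these numbers.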